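Terminal aryl variation: from compound 2 to compound 3

The source may hold more compounds than are shown below. What is called first, only, known or untested is meant among the compounds shown, and "the series" means these compounds.

Going by the values given here, compound 2 `CC(C)C[C@H](N)CN(C(=O)[C@@H]1C[C@H]1c1ccccc1)c1ccc(-c2ccccc2F)cc1` gives 1600 nM in a functional assay for agonist activity at G protein-coupled receptor 88 (Homo sapiens), read by HTRF and cAMP accumulation (on this read-out lower numbers stand for an effect already at smaller amounts and higher numbers for an effect only at larger amounts of compound), the lowest of the two numbers so far; compound 1 `CC(C)C[C@H](N)CN(C(=O)[C@@H]1C[C@H]1c1ccccc1)c1ccc(-c2cccnc2)cc1` gives 10000 nM. Among the compounds with values here, the only measured step is a 6.3-fold lower number from compound 1 to compound 2 (0.80 log units; beyond the scatter), a swap of the distal aryl group. Compound 3 `CC(C)C[C@H](N)CN(C(=O)[C@@H]1C[C@H]1c1ccccc1)c1ccc(-c2ccc(C#N)cc2)cc1` carries 4-cyanophenyl in place of 2-fluorophenyl on an aromatic carbon. Within the data shown here, no measured step involves a nitrile, so direction and size rest on little; the expected step of a 1.6-fold higher number from compound 2 to compound 3 (0.19 log units; within the scatter) is modest and tilted toward a higher number, because compound 1 with its heteroaryl ring gave 10000 nM. Compound 3 is estimated at 2500 nM, range 800 nM to 8000 nM.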

Compound 3, half-maximal effective concentration: 670 nM
Compound 3: the middle estimate sits 3.7-fold (0.57 log units) above what was measured; measured number outside the range, below it.
By their numbers in this assay, from the lowest: compound 3; then compound 2; then compound 1.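

Going by these compounds alone, compound 3 sets the lowest number so far, with a 2.4-fold lower number from compound 2 to compound 3 (0.38 log units; beyond the scatter) and a 15-fold lower number from compound 1 to compound 3 (1.17 log units; beyond the scatter). A fluorine on the terminal phenyl is therefore not required for a lower number, although this swap removes the fluorine and adds the nitrile in one step, so their contributions cannot be separated. No measurement available here accounts for the gain.

Still open is whether the nitrile's placement on the ring matters, as the compounds shown offer no positional comparison. Also open, from the compounds shown here alone, is how a 4-methoxyphenyl, 4-carboxyphenyl or 4-aminomethylphenyl group would compare with 4-cyanophenyl.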